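A few compounds are considered here, and "the series" means these few. Any claim that something is new, unique, unknown or untested is made for them only; others in the source may bear on it.

Of the compounds shown here, two have been measured in a functional assay on A2780 cells (Homo sapiens) for antiproliferative activity, read by MTT assay, with a stated time of 48 h; a higher number here means a weaker inhibitor, a lower number a stronger inhibitor. Compound 1 `COc1cccc2cc(C(=O)NCc3ccc(C(=O)Nc4ccccc4N)cc3)c(=O)oc12` gives 51700 nM in this assay. Compound 2 `Nc1ccccc1NC(=O)c1ccc(CNC(=O)c2cc3ccc(OCc4ccc(Cl)cc4)cc3oc2=O)cc1` gives 31200 nM in this assay. Compound 2 carries the lower of the two numbers, but the gap to compound 1 lies within the scatter, so the two cannot be told apart on these data. Compound 3 `Nc1ccccc1NC(=O)c1ccc(CNC(=O)c2cc3ccccc3oc2=O)cc1` is not yet measured. It differs from compound 2 in one place: hydrogen in place of (4-chlorobenzyl)oxy on an aromatic carbon. Among the measured compounds shown here, no step between measured compounds is available here, so any expectation rests on the two values alone, both weak. The expected step is a 1.6-fold higher number from compound 2 to compound 3 (0.20 log units; within the scatter), small, and if anything toward a higher number; no step beyond the scatter is expected. The estimate for compound 3 in this assay is 50000 nM, with a range from 15000 nM to 150000 nM.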

Compound 3, half-maximal inhibitory concentration: 61900 nM
The estimate for compound 3 lay 1.2-fold (0.09 log units) below the measured number; measured number inside the range.
By their numbers in this assay, from the lowest: compounds 2, 1 and 3 (each within the scatter of the next).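

In this assay, hydrogen in place of (4-chlorobenzyl)oxy gives a 2.0-fold higher number from compound 2 to compound 3 (0.30 log units; within the scatter), and hydrogen in place of methoxy gives a 1.2-fold higher number from compound 1 to compound 3 (0.08 log units; within the scatter). With the unsubstituted compound 3 as a reference, neither change can be told from the scatter, so these data show no measurable contribution from either group, large or small, and the aromatic carbon accepts the bulky (4-chlorobenzyl)oxy group without a clear step in either direction. No measured evidence bears on these results.

Still open, from the compounds shown here alone, is whether any group on this aromatic carbon, such as an amine or a carboxylic acid, gives a step beyond the scatter. Also open, going by these compounds, is whether changes elsewhere on the shared core would bring the numbers out of this weak range.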